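The source may report more compounds than this note shows. Statements on the series, on what has been measured and on what is new or still open speak of the compounds shown alone.

Three compounds share one core and differ only in the chain and the group on its amine nitrogen. Compound 1 `O=S(=O)(NCCCNc1nccc(-c2c(-c3cccc(F)c3)nc3sccn23)n1)c1ccc(Cl)cc1` carries a (4-chlorophenyl)sulfonyl group on that nitrogen, and in a functional assay on SK-MEL-28 cells (Homo sapiens) for cytotoxicity, read by MTT assay (on this read-out lower numbers stand for stronger inhibition and higher numbers for weaker inhibition), compound 1 gives 8450 nM. Compound 2 `Cc1ccc(S(=O)(=O)NCCNc2nccc(-c3c(-c4cccc(F)c4)nc4sccn34)n2)cc1`, in which ((4-methylphenyl)sulfonyl)amino replaces (((4-chlorophenyl)sulfonyl)amino)methyl, reaches only a limit of the assay, > 20000 nM. Compound 3 `O=C(NCCCNc1nccc(-c2c(-c3cccc(F)c3)nc3sccn23)n1)c1ccc(Cl)cc1`, the (4-chlorophenyl)carbonyl amide, likewise sits at a limit, > 20000 nM. Compound 3 therefore stands at the weak end of the numbers seen, at the limit of > 20000 nM in this assay, at which 2 of the 3 values shown sit. Compound 4 `O=S(=O)(NCCCNc1nccc(-c2c(-c3cccc(F)c3)nc3sccn23)n1)c1ccccc1` differs from compound 3 by phenylsulfonyl in place of (4-chlorophenyl)carbonyl on an amine nitrogen. Among the measured compounds shown here, two measured steps bear on this change: an at least 2.3-fold higher number from compound 1 to compound 3 (0.37 log units; beyond the scatter) shows the sulfonyl group outperforming the carbonyl, while an at least 2.3-fold higher number from compound 1 to compound 2 (0.37 log units; beyond the scatter) shows that the chain and ring substituent also matter. Since compound 4 keeps the sulfonyl but drops the chlorine, the step of an at least 1.6-fold lower number from compound 3 to compound 4 (0.22 log units; that floor lies within the scatter) is expected to recover part of what the amide lost. The estimate for compound 4 is 12000 nM, between 5000 nM and 25000 nM.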

Compound 4, half-maximal inhibitory concentration: 6850 nM
For compound 4 the middle estimate is 1.8-fold (0.24 log units) above the measured one; measured number inside the range.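

In this assay, hydrogen in place of chloro on the aromatic carbon gives a 1.2-fold lower number from compound 1 to compound 4 (0.09 log units; within the scatter), so this read-out does not separate the two phenylsulfonyl-type compounds. The step of an at least 2.9-fold lower number from compound 3 to compound 4 (0.46 log units; beyond the scatter), with phenylsulfonyl in place of (4-chlorophenyl)carbonyl on the amine nitrogen, shows that the gain of the sulfonyl compounds over the amide does not depend on the chlorine. The step of an at least 2.9-fold lower number from compound 2 to compound 4 (0.46 log units; beyond the scatter), with ((phenylsulfonyl)amino)methyl in place of ((4-methylphenyl)sulfonyl)amino, is likewise only a floor, and both this step and the one from the amide start from a limit: the limit of > 20000 nM in this assay, at which 2 of the 4 values shown sit.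

As far as these compounds go, compound 2 differs from compound 4 in both the chain and the methyl group, so which of them carries that step stays open. Also open, from the compounds shown here alone, is how a longer chain, or a methoxy group on the phenyl ring, would read here.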